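This account rests on a few compounds, and the source may have more. Where it says the series, first, only, none or still open, it means among the compounds named here.

Measured in a functional assay on MDA-MB-435S cells (Homo sapiens) for cytotoxicity, read by MTT assay, with a stated time of 72 h; a higher number here means a weaker inhibitor, a lower number a stronger inhibitor:

compound 1 `Cc1ccc2oc(CSc3nnc(C)s3)cc(=O)c2c1`: > 25000 nM
compound 2 `Cc1nnc(SCc2coc3ccc(Cl)cc3c2=O)o1`: 3300 nM
compound 3 `Cc1nnc(SCc2coc3ccccc3c2=O)o1`: 1200 nM

The entry for compound 1 is a limit of this assay and not a number (the limit of > 25000 nM in this assay, at which 1 of the 3 values shown sits). Among the two numbers shown, compound 3 holds the lowest; compound 2 sits higher, and the single measured step between them, a 2.8-fold lower number from compound 2 to compound 3 (0.44 log units; beyond the scatter), lies beyond the scatter. That step concerns hydrogen in place of chloro on an aromatic carbon and says nothing about the heteroaryl attached to the sulfur.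

Compound 4 `Nc1nnc(SCc2coc3ccccc3c2=O)s1` is not yet measured. It differs from compound 3 in one place: 5-amino-1,3,4-thiadiazol-2-yl in place of 5-methyl-1,3,4-oxadiazol-2-yl on a sulfur. Going by the values given here, no measured step touches a change of this kind; compound 1 rests on a different core, so its limit offers no direction either. With nothing in the measured series pointing up or down, the expectation for compound 4 in this assay is a step that stays within the scatter, a 1.3-fold higher number from compound 3 to compound 4 (0.10 log units; within the scatter). From the compounds shown here alone, compound 4 is accordingly estimated at 1500 nM, with a range from 500 nM to 5000 nM, the breadth reflecting that the change is untested here.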

Compound 4, half-maximal inhibitory concentration: 950 nM
Estimate against measurement, compound 4: 1.6-fold (0.20 log units) above; low and high end bracket the measured number.
By their numbers in this assay, from the lowest: compounds 4 and 3 (each within the scatter of the next); then compound 2. At a limit, above all of these: compound 1.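

Going by these compounds alone, on a sulfur whose other neighbours are a saturated chain carbon, the one exchange of the heteroaryl group gives a 1.3-fold lower number from compound 3 to compound 4 (0.10 log units; within the scatter) in this assay, so the number does not move readably when 5-amino-1,3,4-thiadiazol-2-yl stands in for 5-methyl-1,3,4-oxadiazol-2-yl. The exchange alters the ring hetero atoms and the substituent at once, and the entering group carries a hydrogen-bond donor that the leaving group lacks, yet the two compounds remain within the scatter of each other, which the earlier step on the chloro group, made elsewhere on the shared core, could not show. Nothing measured here bears on why the two groups read alike.

Ring atoms and substituent change together in this step, so their separate shares stay unresolved, and whether a carboxylic acid on the heteroaryl group or a plain phenyl on the sulfur would hold the number in this range remains open. Compound 1 gives > 25000 nM, a limit of this assay, and rests on a different core, so it cannot separate the two.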